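Adenine-type amide series: methylsulfanyl added at the core

The source may hold more compounds than are shown below. What is called first, only, known or untested is meant among the compounds shown, and "the series" means these compounds.

Measured so far:
compound 1, `COc1ccc(NC(=O)CSc2nc3c(N)ncnc3[nH]2)cc1OC` — 5 nM
compound 2, `COc1ccc(NC(=O)CSc2nc3c(SC)nc(N)nc3[nH]2)cc1OC` — 3650 nM

In an assay on isolated protein for inhibition of Ectonucleotide pyrophosphatase/phosphodiesterase family member 1 (Homo sapiens), using Lineweaver-Burk analysis (a lower number here means a stronger inhibitor, a higher number a weaker inhibitor), compound 1 gives 5 nM, the lower of the two numbers recorded. Going by the values given here, the only other measured member, compound 2, gives 3650 nM in this assay, a gap that lies beyond the usual scatter; compound 2 differs from compound 1 in more than one place, so no single step links the pair.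

Compound 3, `COc1ccc(NC(=O)CSc2nc3c(N)nc(SC)nc3[nH]2)cc1OC`, is not yet measured. It keeps the amino group of compound 1 where it stands and differs only by methylsulfanyl in place of hydrogen on an aromatic carbon.

Among the compounds with values here, no step is recorded that isolates this change. With the amino group retained, the expectation is a moderate weakening rather than a collapse, and the step from compound 1 to compound 3 is estimated at a 5.0-fold higher number from compound 1 to compound 3 (0.70 log units; beyond the scatter), which may still fall close to the scatter. The number for compound 3 in this assay is accordingly expected near 25 nM, with a plausible range from 5 nM to 150 nM.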

Compound 3, inhibition constant: 152 nM
Compound 3: middle estimate off by 6.1-fold (0.78 log units), on the low side; measured number outside the range, above it.
By their numbers in this assay, from the lowest: compound 1; then compound 3; then compound 2.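

In this assay the methylsulfanyl placed on the aromatic carbon between two ring nitrogen atoms comes with a 30-fold higher number from compound 1 to compound 3 (1.48 log units; beyond the scatter) and shows that this position of the core of compound 1 does not accept the change without a large loss. Going by these compounds alone, this is the first reading that isolates the position with the amino group left where it stands, which the earlier pair could not give, as compound 2 differs from compound 1 in more than one place. No measurement at hand bears on the reason for a step of this size.

Going by these compounds, it remains open whether the step belongs to methylsulfanyl itself or to any group on this carbon; fluorine, methyl, an amino group or a longer chain such as propylsulfanyl at the same place would separate those readings. On these data alone, it is also open whether the step keeps its size when the amide side of the molecule is changed, for example with a carboxylic acid on the aromatic ring of that side.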